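Swapping the aryl group on the core of compound 3

The source may hold more compounds than are shown below. What is called first, only, known or untested is meant among the compounds shown, and "the series" means these compounds.

The three measured compounds share one core and differ only in the ring attached through the acetyl chain. Compound 1 `CCOc1ncc(-c2nc(C(F)(F)F)sc2N2CCN(C(=O)Cn3ccc4cccnc43)[C@H](C)C2)cn1` gives 47 nM in an assay on blood for inhibition of C-X-C chemokine receptor type 3 (Homo sapiens), with a stated time of 30 min; on this read-out lower numbers stand for stronger inhibition and higher numbers for weaker inhibition. Compound 2 `CCOc1ncc(-c2nc(C(F)(F)F)sc2N2CCN(C(=O)Cn3nccc3C)[C@H](C)C2)cn1` gives 289 nM, and compound 3 `CCOc1ncc(-c2nc(C(F)(F)F)sc2N2CCN(C(=O)Cn3nc(C)nc3C)[C@H](C)C2)cn1` gives 364 nM. Compound 3 thus stands highest of the three numbers: a 7.7-fold higher number from compound 1 to compound 3 (0.89 log units; beyond the scatter), while a 1.3-fold higher number from compound 2 to compound 3 (0.10 log units; within the scatter). The related step of a 6.1-fold higher number from compound 1 to compound 2 (0.79 log units; beyond the scatter) points the same way.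

Compound 4 `Cc1nc(C)n(CC(=O)N2CCN(c3sc(C(F)(F)F)nc3-c3ccc(C(F)(F)F)nc3)C[C@H]2C)n1` is the next compound. It changes a different part of the structure: 6-(trifluoromethyl)pyridin-3-yl in place of 2-ethoxypyrimidin-5-yl on an aromatic carbon. Going by the values given here, none of the measured steps touches this aromatic carbon; all three concern the ring on the saturated chain carbon bound to the carbonyl carbon. There is therefore no measured step that bears directly on this change, and its size in this assay cannot be read from the shown data. In the absence of such a precedent, the step is expected to be a 1.0-fold lower number from compound 3 to compound 4 (0.02 log units; within the scatter), that is, no change beyond the scatter in either direction. Compound 4 is accordingly estimated at 350 nM in this assay, with a range from 120 nM to 1100 nM that reflects the lack of any comparable measured step.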

Compound 4, half-maximal inhibitory concentration: 860 nM
For compound 4 the middle estimate is 2.5-fold (0.39 log units) below the measured one; measured number inside the range.
By their numbers in this assay, from the lowest: compound 1; then compounds 2 and 3 (each within the scatter of the next); then compound 4.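

At the aromatic carbon next to the ring nitrogen of the shared core, the aryl group is not a silent part of the structure in this assay: 6-(trifluoromethyl)pyridin-3-yl in place of 2-ethoxypyrimidin-5-yl gives a 2.4-fold higher number from compound 3 to compound 4 (0.37 log units; beyond the scatter) on an otherwise unchanged compound. Going by these compounds alone, until now, every measured step had concerned the ring on the saturated chain carbon bound to the carbonyl carbon, so this is the first sign that the number also responds to a change at this second site. The swap alters the ring and its substituent together, and nothing available accounts for the step or says which part of the swap carries it.

Within the data shown here, the aryl swap is seen only with 3,5-dimethyl-1H-1,2,4-triazol-1-yl on the chain, so it remains open whether it would give a similar step with the fused ring of compound 1. Also open, on these data alone, is how this aromatic carbon would respond to a pyrimidine bearing an amine in place of the ethoxy group, or to a pyridine bearing a nitrile in place of the trifluoromethyl group.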